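A few compounds are considered here, and "the series" means these few. Any claim that something is new, unique, unknown or untested is made for them only; others in the source may bear on it.

Working notes on the series. Two compounds carry a measured value in a functional assay (cardiac atrium) for agonist activity, with Cavia porcellus as the target; a lower number here means that less compound is needed, a higher number that more compound is needed for the effect. Compound 1 `CC1=NC(C)=C([N+](=O)[O-])C(c2ccccn2)/C1=C(\O)OC(C)(C)C` gives 1810000 nM in this assay, the highest of the two numbers. Compound 2 `CCO/C(O)=C1\C(C)=NC(C)=C([N+](=O)[O-])C1c1cccnc1` gives 8840 nM in this assay, a lower number that lies beyond the scatter; it differs from compound 1 in more than one place, so only the two values themselves are compared. Compound 3 `CC1=NC(C)=C([N+](=O)[O-])C(c2ccccn2)/C1=C(\O)OCC(C)C` awaits measurement in this assay. It differs from compound 1 as follows: isobutyl in place of tert-butyl on an oxygen on an unsaturated carbon. Among the compounds with values here, no measured step of this kind exists, so the direction rests on the change alone. A moderate drop in the number is expected, a 7.2-fold lower number from compound 1 to compound 3 (0.86 log units; beyond the scatter), without the gap to compound 2 being closed. Compound 3 is estimated at 250000 nM, in the range 50000 nM to 1200000 nM.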

Compound 3, half-maximal effective concentration: 9100 nM
Estimate against measurement, compound 3: 27-fold (1.44 log units) above, and the stated range ends above it.
By their numbers in this assay, from the lowest: compounds 2 and 3 (each within the scatter of the next); then compound 1.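

Isobutyl in place of tert-butyl on an oxygen on an unsaturated carbon gives a 200-fold lower number from compound 1 to compound 3 (2.30 log units; beyond the scatter) in this assay, the first measured step at this position. The same atoms, joined differently, are enough to move the number this far, so this position is sensitive to how the chain is built. Nothing measured here bears on the reason for the step. From the compounds shown here alone, whether a longer chain such as n-hexyl or a benzyl group on the same oxygen lowers the number further remains open. Going by these compounds, it is also open whether a cyclopropylmethyl group would keep the value of compound 3.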